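Benzoxazolyl for Isopropylpyrazolyl: Expected Microsomal Clearance

This account rests on a few compounds, and the source may have more. Where it says the series, first, only, none or still open, it means among the compounds named here.

In an ADME assay (liver) for metabolic stability, with Liver microsome (Homo sapiens) as the target, using microsomes and NADPH, with a stated time of 30 min, tested at 1 uM (a higher number here means faster removal of the compound, a lower number slower removal), compound 1 `CC(C)n1cc(-c2cc(C(O)(C(F)(F)F)C(F)(F)F)cnc2N2CCN(S(=O)(=O)c3ccc(N)nc3)CC2)cn1` gives 38 mL.min-1.g-1, the second highest of the three numbers at hand. Compound 2 `CC(C)(C)n1cc(-c2cc(C(O)(C(F)(F)F)C(F)(F)F)cnc2N2CCN(S(=O)(=O)c3ccc(N)nc3)CC2)cn1` gives 86 mL.min-1.g-1, and compound 3 `Nc1ccc(S(=O)(=O)N2CCN(c3ncc(C(O)(C(F)(F)F)C(F)(F)F)cc3-c3cccc(F)c3)CC2)cn1` gives 25 mL.min-1.g-1. The step of a 2.3-fold higher number from compound 1 to compound 2 (0.35 log units; beyond the scatter) lies beyond the scatter, whereas a 1.5-fold lower number from compound 1 to compound 3 (0.18 log units; within the scatter) does not, and a 3.4-fold lower number from compound 2 to compound 3 (0.54 log units; beyond the scatter) is modest. Compound 4 `Nc1ccc(S(=O)(=O)N2CCN(c3ncc(C(O)(C(F)(F)F)C(F)(F)F)cc3-c3ccc4ocnc4c3)CC2)cn1` differs from compound 1 by 1,3-benzoxazol-5-yl in place of 1-isopropyl-1H-pyrazol-4-yl on an aromatic carbon. For the measured compounds named here, the only comparable exchanges of the group at that position are the steps leading to compound 3, one within the scatter starting from compound 1 and one modest fall starting from compound 2, so little movement is expected here. Compound 4 is therefore estimated at 30 mL.min-1.g-1, within a range from 12 mL.min-1.g-1 to 75 mL.min-1.g-1, which is an expected step of a 1.3-fold lower number from compound 1 to compound 4 (0.10 log units; within the scatter).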

Compound 4, intrinsic clearance in microsomes: < 14 mL.min-1.g-1
Compound 4 ended at the assay's limit (the forecaster's own chance of this, stated with the estimate: 5%); at least 2.1-fold (0.33 log units) between middle value and limit.
By their numbers in this assay, from the lowest: compounds 3 and 1 (each within the scatter of the next); then compound 2. At a limit, below all of these: compound 4.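

In this assay compound 4 reads as a limit, not a number: the limit of < 14 mL.min-1.g-1 in this assay, at which 1 of the 4 values shown sits. Even so, replacing 1-isopropyl-1H-pyrazol-4-yl with 1,3-benzoxazol-5-yl at this position gives a clear drop, with an at least 2.7-fold lower number from compound 1 to compound 4 (0.43 log units; beyond the scatter) and an at least 6.1-fold lower number from compound 2 to compound 4 (0.78 log units; beyond the scatter), whereas the exchange for 3-fluorophenyl starting from compound 1 stayed within the scatter. Against that 3-fluorophenyl group only a floor can be read, an at least 1.7-fold lower number from compound 3 to compound 4 (0.25 log units; that floor lies within the scatter), so the two aryl groups are not separated. The compounds shown leave open how far the true number of compound 4 lies past the limit. They also leave open whether a 1,3-benzothiazol-5-yl or an unsubstituted phenyl group on this aromatic carbon would give a similar reading.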